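Boronic Acid in Place of Carboxymethoxy on a Chalcone Scaffold

The source may report more compounds than this note shows. Statements on the series, on what has been measured and on what is new or still open speak of the compounds shown alone.

Three chalcone analogues were examined in a functional assay on MCF-12A cells (Homo sapiens) for inhibition; a higher number here means a weaker inhibitor, a lower number a stronger inhibitor. Compound 1 `O=C(/C=C/c1ccc(I)cc1)c1ccc(OCB(O)O)cc1` gives 100000 nM, compound 2 `O=C(/C=C/c1ccc(F)c(Br)c1)c1ccc(B(O)O)cc1` gives 38000 nM, and compound 3 `O=C(O)COc1ccc(/C=C/C(=O)c2ccc(Cl)c(Cl)c2)cc1` gives 28000 nM. Compound 3 thus shows the lowest of the three numbers, though its gap to compound 2 lies within the scatter, while its gap to compound 1 lies beyond it. Compound 4 `O=C(/C=C/c1ccc(B(O)O)cc1)c1ccc(Cl)c(Cl)c1` is the next analogue, differing from compound 3 by a group of 3 heavy atoms (1 boron, 2 oxygen; no ring) in place of a group of 5 heavy atoms (2 carbon, 3 oxygen; no ring), on an aromatic carbon, on an aromatic carbon of a six-membered aromatic ring of carbon only, para to a large group. Because compound 1 gives 100000 nM and compound 2 gives 38000 nM, both carrying boronic acid, the step of a 1.3-fold higher number from compound 3 to compound 4 (0.10 log units; within the scatter) is expected to be small and not beyond the scatter. Compound 4 is estimated at 35000 nM, within 12000 nM to 100000 nM.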

Compound 4, half-maximal inhibitory concentration: 15000 nM
Compound 4: the middle estimate sits 2.3-fold (0.37 log units) above what was measured; low and high end bracket the measured number.
By their numbers in this assay, from the lowest: compounds 4, 3 and 2 (each within the scatter of the next, the first and the last beyond it); then compound 1.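

In this assay, putting the boronic acid in place of carboxymethoxy on this aromatic carbon, para to a large group, gives a 1.9-fold lower number from compound 3 to compound 4 (0.27 log units; within the scatter). Within the data shown here, this is the first direct comparison of the two groups at this position, and the read-out does not separate them, although the entering group has fewer heavy atoms. Nothing measured here bears on why this is so.

The compounds shown leave open how a nitrile or a primary amide would read at this position. They also leave open whether the same exchange gives a similar step with the halogens of compound 2.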